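Swapping Methoxy for Trifluoromethylsulfanyl on Dichloroacetamides

This account rests on a few compounds, and the source may have more. Where it says the series, first, only, none or still open, it means among the compounds named here.

Measured so far:
compound 1 `COc1cccc(NC(=O)C(Cl)Cl)c1` gives 179000 nM in a functional assay on BGC-823 cells (Homo sapiens) for antiproliferative activity, read by MTT assay, with a stated time of 72 h; on this read-out higher numbers stand for weaker inhibition and lower numbers for stronger inhibition;
compound 2 `O=C(Nc1cccc(SC(F)(F)F)c1)C(Cl)Cl` gives 123000 nM in this assay.

Compound 3 `COc1ccc(NC(=O)C(Cl)Cl)cc1` gives "not determined" (no result reported) in this assay, so it has no single number there. Compound 4 `O=C(Nc1ccc(SC(F)(F)F)cc1)C(Cl)Cl` is not yet measured. Compound 2 arises from compound 1 by (trifluoromethyl)sulfanyl in place of methoxy on an aromatic carbon, and that change gave a 1.5-fold lower number from compound 1 to compound 2 (0.16 log units; within the scatter). Compound 4 arises from compound 3 by the same kind of change, ((trifluoromethyl)sulfanyl in place of methoxy on an aromatic carbon); here the group sits para to a group of 6 heavy atoms, whereas in compound 2 it sits meta to a group of 6 heavy atoms. The difference between the two cores is not broken down here. With compound 3 unmeasured, the expectation for compound 4 rests on compound 1 and compound 2 alone, both weak inhibitors, so a similarly weak value is estimated, around 120000 nM, between 40000 nM and 300000 nM.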

Compound 4, half-maximal inhibitory concentration: 203000 nM
For compound 4 the middle estimate is 1.7-fold (0.23 log units) below the measured one; measured number inside the range.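

In this assay, going by these compounds alone, compound 3 has no single number, so no step from compound 3 to compound 4 can be read. From the compounds shown here alone, whether swapping methoxy for (trifluoromethyl)sulfanyl shifts the number when the group sits para to a group of 6 heavy atoms stays open. No data here point to a cause.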